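Urea in place of amide at a diaryl pyrazole periphery

The compounds below may be only part of what the source reports. "The series", "measured", "known", "first", "only" and "open" are said of these compounds alone.

Compound 1 `COc1cc(Cl)cc(-c2nn(-c3cccc(NC(=O)Nc4ccc(Cl)c(C(F)(F)F)c4)c3)cc2-c2ccncc2)c1`: 3.99%
Compound 2 `COc1cc(Cl)cc(-c2nn(-c3cccc(NC(=O)c4cc(C(F)(F)F)cc(C(F)(F)F)c4)c3)cc2-c2ccncc2)c1`: 67.3%
Compound 3 `COc1cc(Cl)cc(-c2nn(-c3cccc(NC(=O)c4cccc(C(F)(F)F)c4)c3)cc2-c2ccncc2)c1`: 56.3%

In a functional assay on M14 cells (Homo sapiens) for inhibition, read by sulforhodamine B assay, with a stated time of 48 h, tested at 10 uM (on this read-out higher numbers stand for a weaker effect at the one concentration tested and lower numbers for a stronger effect), compound 3 gives 56.3%, the second highest of the three numbers. Its nearest neighbour is compound 2, with a number 11 percentage points lower from compound 2 to compound 3 (beyond the scatter); its furthest is compound 1, with a number 52.3 percentage points higher from compound 1 to compound 3 (beyond the scatter). Compound 4 `COc1cc(Cl)cc(-c2nn(-c3cccc(NC(=O)Nc4ccc(Cl)c(Cl)c4)c3)cc2-c2ccncc2)c1` differs from compound 3 at the carbonyl carbon: (3,4-dichlorophenyl)amino in place of 3-(trifluoromethyl)phenyl on a carbonyl carbon. Going by the values given here, the only step that bears on this change is the one between compound 1 and compound 3, which was large, and compound 4 carries the same kind of carbamoyl as compound 1. The change is therefore expected to run the other way in this assay , as a large fall, a number 48.3 percentage points lower from compound 3 to compound 4 (beyond the scatter). Compound 4 is estimated at 8%, within 2% to 30%.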

Compound 4, a percentage reported as activity, at one concentration (the size of the read-out at that concentration, not a potency): 18.7%
The estimate for compound 4 lay 10.7 percentage points below the measured number; measured number inside the range.
By their numbers in this assay, from the lowest: compound 1; then compound 4; then compound 3; then compound 2.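

In this assay, a second urea repeats the finding from compound 1: (3,4-dichlorophenyl)amino on the carbonyl carbon gives a number 37.6 percentage points lower from compound 3 to compound 4 (beyond the scatter), so the low number is not confined to compound 1. The aromatic substituent also matters among the ureas, with chloro in place of trifluoromethyl giving a number 14.7 percentage points higher from compound 1 to compound 4 (beyond the scatter). No evidence is available to explain either step.

As far as these compounds go, compound 3 and compound 4 also differ in their ring substituents, so the share of the urea nitrogen itself remains open. From the compounds shown here alone, how a morpholine or a carboxylic acid on the aromatic ring would read also remains open.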